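Compound 3 to compound 4: a chain gives way to a ring

A few compounds are considered here, and "the series" means these few. Any claim that something is new, unique, unknown or untested is made for them only; others in the source may bear on it.

compound 1 `CCNC(=O)c1nnn(-c2cc(C(C)C)c(O)cc2O)c1-c1ccc(CN2CCC[C@H](O)C2)cc1` gives 70 nM
compound 2 `CCNC(=O)c1nnn(-c2cc(C(C)C)c(O)cc2O)c1-c1ccc(CNC2CCCCC2)cc1` gives 15 nM
compound 3 `CCNC(=O)c1nnn(-c2cc(C(C)C)c(O)cc2O)c1-c1ccc(CNCCCN(CC)CC)cc1` gives 412 nM

These three share a core and differ only in the amine group. In a functional assay on NCI-H460 cells (Homo sapiens) for inhibition, read by sulforhodamine B assay, with a stated time of 72 h (a lower number here means a stronger inhibitor, a higher number a weaker inhibitor), compound 3 has the highest number of the three (412 nM), which makes it the weakest inhibitor so far.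

Compound 4 (`CCNC(=O)c1nnn(-c2cc(C(C)C)c(O)cc2O)c1-c1ccc(CNC2CCN(C)CC2)cc1`) keeps the shared core and changes one group, with 1-methylpiperidin-4-yl in place of 3-(diethylamino)propyl on an amine nitrogen. An open chain leaves and a six-membered non-aromatic ring enters.

Among the compounds with values here, two measured steps bear on this swap, since both involve the same chain and a six-membered ring group. Replacing cyclohexyl with that chain gave a large step (a 27-fold higher number from compound 2 to compound 3 (1.44 log units; beyond the scatter)). Replacing 3-hydroxypiperidin-1-yl with it gave a modest one (a 5.9-fold higher number from compound 1 to compound 3 (0.77 log units; beyond the scatter)). Within the data shown here, the two ring groups also differ from each other (a 4.7-fold lower number from compound 1 to compound 2 (0.67 log units; beyond the scatter)), so the ring alone does not fix the outcome, and no measured compound carries the incoming group.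

A lower number in this assay is therefore expected, with a modest rather than large step (a 4.6-fold lower number from compound 3 to compound 4 (0.66 log units; beyond the scatter)). Compound 4 is expected at about 90 nM (estimated range 25 nM to 300 nM).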

Compound 4, half-maximal inhibitory concentration: > 1000 nM
Compound 4: a limit, no number; the forecaster's own chance of this, stated with the estimate: 2%; middle value at least 11-fold (1.04 log units) from the limit.
By their numbers in this assay, from the lowest: compound 2; then compound 1; then compound 3. At a limit, above all of these: compound 4.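

In this assay, compound 4 gives only a limit of the assay, not a number: the limit of > 1000 nM in this assay, at which 1 of the 4 values shown sits.

Even so, the direction is clear, and a six-membered non-aromatic ring on this amine nitrogen does not by itself give a lower number than the open chain, as the change shows an at least 2.4-fold higher number from compound 3 to compound 4 (0.38 log units; beyond the scatter). The comparison with the other two amine groups shows an at least 66-fold higher number from compound 2 to compound 4 (1.82 log units; beyond the scatter) and an at least 14-fold higher number from compound 1 to compound 4 (1.15 log units; beyond the scatter), and the first of these is the most telling, since cyclohexyl and 1-methylpiperidin-4-yl are both six-membered non-aromatic rings and the second holds one hetero atom, a nitrogen that carries a methyl group. Among these four compounds, the two whose group carries a further nitrogen, compound 3 and compound 4, have the highest readings, and neither goes against that pattern, though four compounds are a thin basis for it.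

Going by these compounds, whether that ring nitrogen is what matters remains open, and a tetrahydropyran-4-yl group, with an oxygen in its place, or a piperidin-4-yl group, without the methyl, would bear directly on it. On these data alone, how far compound 4 really lies from compound 3 also stays unknown, since only a limit is available.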